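The source may report more compounds than this note shows. Statements on the series, on what has been measured and on what is new or still open speak of the compounds shown alone.

Measured so far in a physicochemical assay for solubility, in phosphate buffer, with a stated time of 2 h, at pH 7.4; a lower number here means a less soluble compound, a higher number a more soluble compound:
- compound 1 `Clc1ccc(Nc2nc(-c3ccccn3)cs2)nc1`: < 10000 nM (a limit)
- compound 2 `COc1ccnc(-c2csc(Nc3ccc(Cl)cn3)n2)c1`: < 10000 nM (a limit)
- compound 3 `Clc1ccc(Nc2nc(-c3ccccn3)c(Cl)s2)nc1`: < 10000 nM (a limit)

Compound 3 reads < 10000 nM in this assay, which is a limit and not a number. It has no readable place among the measured compounds, as all of them sit at one limit: the limit of < 10000 nM in this assay, at which 3 of the 3 values shown sit.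

Compound 4 `COc1ccnc(-c2nc(Nc3ccc(Cl)cn3)sc2Cl)c1` differs from compound 3 by methoxy in place of hydrogen on an aromatic carbon. The change is methoxy in place of hydrogen on an aromatic carbon, on the six-membered aromatic ring with 1 nitrogen, opposite the ring nitrogen.

The closest measured precedent is the same change in a step that the two limits leave unreadable from compound 1 to compound 2. The other measured step, chloro in place of hydrogen on an aromatic carbon, is a step that the two limits leave unreadable from compound 1 to compound 3, and it links compound 3 to the parent of the pair. Neither step has a readable size, so neither gives a direction or a magnitude to carry over. No step beyond the scatter is therefore expected in this assay, and another reading at the same limit is the likeliest outcome.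

The estimated step is a step that the limit leaves unreadable from compound 3 to compound 4.

Compound 4 is estimated at 6000 nM, with an expected range from 1500 nM to 10000 nM.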

Compound 4, solubility: < 10000 nM
Compound 4: a limit, no number (the forecaster's own chance of this, stated with the estimate: 85%); the middle value does not contradict the limit.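

Compound 4 reads < 10000 nM in this assay, which is a limit and not a number. Its steps from compound 3 and from compound 2 therefore cannot be read, and the series stays at one limit: the limit of < 10000 nM in this assay, at which 4 of the 4 values shown sit.

The compounds shown leave open whether methoxy or chloro in place of hydrogen changes solubility at all, and in which direction.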